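A few compounds are considered here, and "the series" means these few. Any claim that something is new, unique, unknown or untested is made for them only; others in the source may bear on it.

Compound 1 `Cc1c(CC(=O)O)c2ccsc2n1S(=O)(=O)c1ccccc1` is the starting point of this account. In an assay on HEK293 cells for displacement of a labelled ligand from prostaglandin D2 receptor 2 (Homo sapiens) (a higher number here means a weaker inhibitor, a lower number a stronger inhibitor), compound 1 gives 2750 nM, the highest of the three numbers at hand. Compound 2 `Cc1c(CC(=O)O)c2ccsc2n1S(=O)(=O)c1ccc(F)cc1` carries a fluoro in place of hydrogen on an aromatic carbon; in this assay compound 2 gives 1630 nM, and the move a 1.7-fold lower number from compound 1 to compound 2 (0.23 log units; within the scatter). Compound 3 `Cc1c(CC(=O)O)c2ccsc2n1S(=O)(=O)c1ccc(S(C)(=O)=O)cc1` carries a methylsulfonyl on an aromatic carbon of the same ring; in this assay compound 3 gives 90 nM, so that a 31-fold lower number from compound 1 to compound 3 (1.49 log units; beyond the scatter), and an 18-fold lower number from compound 2 to compound 3 (1.26 log units; beyond the scatter).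

Compound 4 `Cc1c(CC(=O)O)c2ccsc2n1S(=O)(=O)c1ccc(S(=O)(=O)N2CCOCC2)cc1` has not yet been measured in this assay. It differs from compound 1 in one place: (morpholin-4-yl)sulfonyl in place of hydrogen on an aromatic carbon. The step that bears most directly on this change is the one in which a sulfonyl-bearing group enters on the same aromatic carbon, and that step was large: a 31-fold lower number from compound 1 to compound 3 (1.49 log units; beyond the scatter). The step with fluoro, a 1.7-fold lower number from compound 1 to compound 2 (0.23 log units; within the scatter), stayed within the scatter and offers no guidance. Within the data shown here, no measured step reports the morpholin-4-yl part on its own. A large drop in the number is therefore expected for compound 4, a step of an 18-fold lower number from compound 1 to compound 4 (1.26 log units; beyond the scatter). For compound 4 the estimate in this assay is 150 nM, with a range from 40 nM to 600 nM.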

Compound 4, half-maximal inhibitory concentration: 230 nM
For compound 4 the middle estimate is 1.5-fold (0.19 log units) below the measured one; the measured number falls inside the stated range.
By their numbers in this assay, from the lowest: compound 3; then compound 4; then compounds 2 and 1 (each within the scatter of the next).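

In this assay, the large gain on this aromatic carbon is not confined to the methylsulfonyl group of compound 3, as the much bulkier (morpholin-4-yl)sulfonyl also brings a large drop (a 12-fold lower number from compound 1 to compound 4 (1.08 log units; beyond the scatter)) and a modest one against the fluoro analogue (a 7.1-fold lower number from compound 2 to compound 4 (0.85 log units; beyond the scatter)). What sits on the sulfonyl sulfur still counts, since morpholin-4-yl in place of methyl gives back a modest part of that gain (a 2.6-fold higher number from compound 3 to compound 4 (0.41 log units; beyond the scatter)), so a six-membered non-aromatic ring on the sulfur is accepted but does not match the methyl group. The data at hand offer no explanation for either the gain or the partial loss.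

Going by these compounds, whether the ring itself matters stays open: an open-chain dimethylamino group on the sulfur, or a piperazine ring with a free amine, would separate the ring from the simple presence of a nitrogen there. Also open, on these data alone, is whether a sulfonyl is needed at all on this carbon, which a nitrile, an amide or a carboxylic acid in its place would test, and whether the sulfonyl groups would hold their effect on other carbons of the same ring.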